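Removing a methyl from an oxygen on the aryl ring

The compounds below may be only part of what the source reports. "The series", "measured", "known", "first", "only" and "open" are said of these compounds alone.

Of the compounds shown here, two have been measured in a functional assay on HOP-92 cells (Homo sapiens) for cytotoxicity, read by sulforhodamine B assay, with a stated time of 48 h, tested at 1 uM; a lower number here means a stronger effect, a higher number a weaker effect of the compound at the concentration tested. Compound 1, with structure `Cc1cc(O)cc(-c2nn(CC#N)cc2-c2ccnc(-c3ccc(Oc4ccccc4)cc3)c2)c1`, gives -67% in this assay. Compound 2, with structure `COc1cc(C)cc(-c2nn(CC#N)cc2-c2ccnc(-c3ccc(N(C)C)cc3)c2)c1`, gives 9% in this assay. Among these two numbers, compound 2 stands highest, which means the weaker effect on the cells, and the number for compound 1 lies far lower, well beyond the usual scatter of the measurement. The two compounds differ in more than one place, so no single change can be read from their values.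

Compound 3, with structure `Cc1cc(O)cc(-c2nn(CC#N)cc2-c2ccnc(-c3ccc(N(C)C)cc3)c2)c1`, has not yet been measured. It is made from compound 2 by one change: hydrogen in place of methyl on an oxygen on an aromatic ring. Compound 3 thereby carries the same hydroxy-bearing ring as compound 1, while keeping the dimethylamino-bearing part of compound 2.

Because compound 1 gives -67% with that hydroxy ring, the step is expected to go downward, toward a stronger effect, with an estimated size of a number 29 percentage points lower from compound 2 to compound 3 (beyond the scatter). Among the compounds with values here, for compound 3 the expected value in this assay is -20%, within a range from -70% to 15%, the wide range reflecting that only two compounds are known.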

Compound 3, a percentage reported as activity, at one concentration (the size of the read-out at that concentration, not a potency): 25%
Estimate against measurement, compound 3: 45 percentage points below, outside the stated range (above it).
By their numbers in this assay, from the lowest: compound 1; then compound 2; then compound 3.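

In this assay, replacing methoxy with hydroxy on the 3-methoxy-5-methylphenyl ring gives a number 16 percentage points higher from compound 2 to compound 3 (beyond the scatter), so with dimethylamino on the far ring, the hydroxy group does not bring a stronger effect on the cells. The hydroxy-bearing ring alone therefore cannot account for the low number of compound 1. Within the data shown here, with that ring held constant, the single change of dimethylamino in place of phenoxy on an aromatic carbon gives a number 92 percentage points higher from compound 1 to compound 3 (beyond the scatter), a far larger shift than the one at the oxygen, which ties the strong effect in this pair to phenoxy; no measured evidence here explains either step.

On these data alone, it remains open whether methoxy in place of hydroxy would also raise the number when phenoxy is present, since the step at the oxygen is known only alongside dimethylamino. It is also unknown how a longer chain on that oxygen, such as ethyl, or a different group in place of phenoxy, such as benzyloxy or morpholine, would behave in this assay.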